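A few compounds are considered here, and "the series" means these few. Any claim that something is new, unique, unknown or untested is made for them only; others in the source may bear on it.

Compound 1 `CCCOC1=C(CCC)C(=O)/C(=C(O)/C=C/c2ccccc2)C(=O)C1(CCC)CCC` gives 2.6 uM in a functional assay on HCT-8 cells (Homo sapiens) for antiproliferative activity, read by sulforhodamine B assay, with a stated time of 3 days (on this read-out lower numbers stand for an effect already at smaller amounts and higher numbers for an effect only at larger amounts of compound), the lowest of the three numbers in hand. Compound 2 `CCCC1=C(OCC(C)C)C(CCC)(CCC)C(=O)/C(=C(O)\C=C\c2ccccc2)C1=O` gives 8 uM and compound 3 `CCCCOC1=C(CCC)C(=O)/C(=C(O)/C=C/c2ccccc2)C(=O)C1(CCC)CCC` gives 8.7 uM in this assay. The steps of a 3.1-fold higher number from compound 1 to compound 2 (0.49 log units; beyond the scatter) and a 3.3-fold higher number from compound 1 to compound 3 (0.52 log units; beyond the scatter) both lie beyond the scatter, whereas a 1.1-fold higher number from compound 2 to compound 3 (0.04 log units; within the scatter) stays within it. Compound 4 `CCCOC1=C(CCC)C(=O)/C(=C(O)/C=C/c2ccc(I)cc2)C(=O)C1(CCC)CCC` differs from compound 1 by iodo in place of hydrogen on an aromatic carbon. Among the compounds with values here, every measured step changes the saturated chain bound to the oxygen; none touches the aromatic ring, so no measured step bears directly on this change, and the ring change is untested. The expected step is therefore a 1.1-fold higher number from compound 1 to compound 4 (0.03 log units; within the scatter), nothing beyond the scatter. Compound 4 is expected at 2.8 uM, with a range from 1 uM to 8 uM.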

Compound 4, concentration for half-maximal effect: 7.8 uM
The estimate for compound 4 lay 2.8-fold (0.44 log units) below the measured number; the measured number falls inside the stated range.
By their numbers in this assay, from the lowest: compound 1; then compounds 4, 2 and 3 (each within the scatter of the next).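

Within the data shown here, the aromatic ring is not a silent position: in this assay, iodo in place of hydrogen on an aromatic carbon gives a 3.0-fold higher number from compound 1 to compound 4 (0.48 log units; beyond the scatter) and so a modest step, the only measured change outside the saturated chain bound to the oxygen. No measurement at hand offers a reason for this step. Whether the step is particular to iodo stays open, as the compounds shown include no fluoro, methoxy or carboxylic acid at this place. Also open, as far as these compounds go, is whether the same change behaves alike on a different chain bound to the oxygen, such as the butyl chain of compound 3.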